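Trifluoromethyl for fluoro in a series at the limit

A few compounds are considered here, and "the series" means these few. Any claim that something is new, unique, unknown or untested is made for them only; others in the source may bear on it.

In an ADME assay on MDBK cells (Bos taurus) for cytotoxicity (on this read-out lower numbers stand for higher toxicity in this test and higher numbers for lower toxicity in this test), compound 2 `Fc1ccc(Cn2ccc3nc(-c4ccccc4)nc-3c2)cc1` gives only a limit, > 100000 nM. Compound 1 `COc1cccc(Cn2ccc3nc(-c4ccccc4)nc-3c2)c1` also gives only a limit, > 100000 nM. Compound 3 `N#Cc1ccccc1Cn1ccc2nc(-c3ccccc3)nc-2c1` likewise gives a limit, > 100000 nM.

Compound 4 `FC(F)(F)c1ccc(Cn2ccc3nc(-c4ccccc4)nc-3c2)cc1` carries trifluoromethyl in place of fluoro on an aromatic carbon, para to a large group (trifluoromethyl in place of fluoro on an aromatic carbon).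

The steps bearing on this change are a step that the two limits leave unreadable from compound 1 to compound 2, a step that the two limits leave unreadable from compound 1 to compound 3 and a step that the two limits leave unreadable from compound 2 to compound 3; none has a readable size. The evidence is the limit of > 100000 nM in this assay, at which 3 of the 3 values shown sit. In this assay, no step beyond the scatter is therefore expected, and no direction can be assigned. The expected step is a step that the limit leaves unreadable from compound 2 to compound 4. For compound 4, the estimate is 120000 nM, with an expected range of 40000 nM to 300000 nM.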

Compound 4, half-maximal cytotoxic concentration: 84000 nM
For compound 4 the middle estimate is 1.4-fold (0.15 log units) above the measured one; the measured number falls inside the stated range.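

In this assay, for the compounds shown here, compound 4 gives 84000 nM, the only value shown that is a number and not a limit. The step is an at least 1.1-fold lower number from compound 2 to compound 4 (0.07 log units; that floor lies within the scatter), so trifluoromethyl in place of fluoro on an aromatic carbon, para to a large group, yields only a floor and no established change. The other steps in the series cannot be read: the limit of > 100000 nM in this assay, at which 3 of the 4 values shown sit.

The compounds shown leave open how an amine or a carboxylic acid in this place would read in this assay. They also leave open whether a value well below the limit can be reached at this position.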